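The source may report more compounds than this note shows. Statements on the series, on what has been measured and on what is new or still open speak of the compounds shown alone.

Measured so far:
- compound 1, `COc1ccccc1NC(=O)Oc1cc(=O)n(CCCO)c2c1CC(CC=C(C)C)C(C)(C)C2`: 0%
- compound 2, `COc1cccc(NC(=O)Oc2cc(=O)n(CCCO)c3c2CC(C/C=C(\C)CCC=C(C)C)C(C)(C)C3)c1`: 11.3%

Of the compounds shown here, two have been tested in a functional assay on PANC-1 cells (Homo sapiens) for inhibition, read by MTT assay, with a stated time of 24 h, tested at 10 uM; on this read-out lower numbers stand for less inhibition and higher numbers for more inhibition at the one concentration tested (going by the name of the read-out). Compound 1 gives 0%, no measurable effect at the concentration tested. Compound 2 gives 11.3%, the higher of the two numbers; its distance from compound 1 lies beyond the usual scatter, so the two values do differ. The two compounds differ in more than one place, so nothing can be said about which part of the structure carries that difference.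

Compound 3, `COc1ccccc1NC(=O)Oc1cc(=O)n(CCCO)c2c1CC(C/C=C(\C)CCC=C(C)C)C(C)(C)C2`, has not been measured. It shares the longer side chain of compound 2 and differs from it in one place: 2-methoxyphenyl in place of 3-methoxyphenyl on an amide-type nitrogen. This is the same aromatic substitution pattern that compound 1 carries, where 0% was found. Only two data points are available, so the expected size of the step from compound 2 to compound 3 is uncertain; it is expected to be small and downward, within the scatter, at a number 6.3 percentage points lower from compound 2 to compound 3 (within the scatter). On that basis compound 3 is expected to give about 5%, with a plausible range from 0% to 15%.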

Compound 3, a percentage reported as inhibition, at one concentration (the size of the read-out at that concentration, not a potency): 0%
Beside the measured number, compound 3's estimate is 5 percentage points above it; the range from low to high includes it.
By their numbers in this assay, from the lowest: compounds 1 and 3 (each within the scatter of the next); then compound 2.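

In this assay, among the compounds shown here, 2-methoxyphenyl in place of 3-methoxyphenyl on the amide-type nitrogen gives a number 11.3 percentage points lower from compound 2 to compound 3 (beyond the scatter), the first comparison to show that the two methoxyphenyl groups are not interchangeable here, even though the same atoms are present in both compounds. With 2-methoxyphenyl on that nitrogen, 3-methylbut-2-en-1-yl in place of hydrogen on a saturated chain carbon bound to a double-bonded chain carbon gives no change at the digits printed from compound 1 to compound 3 (within the scatter), so this longer side chain does not lift the reading above zero in this setting. No available measurement explains the difference between the two methoxyphenyl groups.

As far as these compounds go, it remains open whether the longer side chain matters when 3-methoxyphenyl is present, since a change can only be seen against a starting reading above zero, and compound 1 and compound 3 both offer none. From the compounds shown here alone, it is also open how this position would respond to a plain phenyl ring, or to a phenyl ring carrying an amine or a carboxylic acid in place of the methoxy group.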